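Swapping isopropyl for cyclobutyl on the ether chain

This account rests on a few compounds, and the source may have more. Where it says the series, first, only, none or still open, it means among the compounds named here.

Of the compounds shown here, three built on one shared core have been tested in an assay on CHO cells for displacement of a labelled ligand from adenosine receptor A3 (Homo sapiens), read by scintillation counting, with a stated time of 120 min, tested at 1 uM; on this read-out lower numbers stand for less inhibition and higher numbers for more inhibition at the one concentration tested (going by the name of the read-out). Compound 1 `N#Cc1c(N)nc(SCc2cccnc2)c(C#N)c1-c1ccc(OCC2CC2)cc1` gives 19%. Within the data shown here, compound 3 `N#Cc1c(N)nc(SCn2cncn2)c(C#N)c1-c1ccc(OCC2CC2)cc1` gives 1%, and the single one-place step in this set, a number 18 percentage points lower from compound 1 to compound 3 (beyond the scatter), lies on the chain carbon bound to sulfur. Compound 2 `CC(C)COc1ccc(-c2c(C#N)c(N)nc(SCC(N)=O)c2C#N)cc1` gives 9%, a number that sits within the scatter of both compound 1 and compound 3, so no order among these three can be read from it.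

Compound 4 `N#Cc1c(N)nc(SCC(N)=O)c(C#N)c1-c1ccc(OCC2CCC2)cc1` differs from compound 2 in one place: cyclobutyl in place of isopropyl on a saturated chain carbon bound to an oxygen on an aromatic ring. Among the measured compounds shown here, no measured step touches the chain bound to the aromatic oxygen; the only step on record concerns a different part of the molecule, so it gives no guidance here. With nothing to suggest a shift, compound 4 is expected to stay close to compound 2, with a step of a number 1 percentage points higher from compound 2 to compound 4 (within the scatter) that lies within the scatter. The estimate for compound 4 in this assay is 10%, expected to fall between 0% and 25%.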

Compound 4, a percentage reported as inhibition, at one concentration (the size of the read-out at that concentration, not a potency): 1%
The estimate for compound 4 lay 9 percentage points above the measured number, within the range that was stated.
By their numbers in this assay, from the lowest: compounds 3, 4, 2 and 1 (each within the scatter of the next, the first and the last beyond it).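

Among these compounds, this is the first measured step on the chain bound to the aromatic oxygen: in this assay, cyclobutyl in place of isopropyl gives a number 8 percentage points lower from compound 2 to compound 4 (within the scatter). Read cut one bond further out, isobutoxy to cyclobutylmethoxy adds a four-membered ring of carbon at this place, yet the result cannot be told apart from the usual spread of repeated measurements, so no effect of the change can be claimed. No available evidence bears on this result.

Going by these compounds, what a longer chain or an amine would do on the saturated chain carbon bound to an oxygen on an aromatic ring remains open. On these data alone, it is also open whether the same swap would read alike with pyridin-3-yl or 1H-1,2,4-triazol-1-yl on the chain carbon bound to sulfur.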